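Oxolan-3-yl on the amide-type nitrogen: clearance notes

The source may hold more compounds than are shown below. What is called first, only, known or untested is meant among the compounds shown, and "the series" means these compounds.

In an in vitro ADME assay on microsomes (Homo sapiens) for metabolic stability (a higher number here means faster removal of the compound, a lower number slower removal), compound 1 `COCC(C)N(CC(=O)Nc1cc(F)cc(F)c1)C(=O)c1ccc(-c2ccccn2)cc1` gives 5.8 mL.min-1.g-1 and compound 2 `CCC(COC)N(CC(=O)Nc1cc(F)cc(F)c1)C(=O)c1ccc(-c2ccccn2)cc1` gives 9.6 mL.min-1.g-1, so compound 2 stands within the scatter of compound 1. Compound 3 `O=C(CN(C(=O)c1ccc(-c2ccccn2)cc1)C1CCOC1)Nc1cc(F)cc(F)c1` differs from compound 2 by oxolan-3-yl in place of 1-(methoxymethyl)propyl on an amide-type nitrogen. For the measured compounds named here, the only measured step in this substituent, a 1.7-fold higher number from compound 1 to compound 2 (0.22 log units; within the scatter), lies within the scatter, and no measured step introduces a ring, so the support is thin. The estimated change is a 1.4-fold lower number from compound 2 to compound 3 (0.14 log units; within the scatter), which is not expected to exceed the scatter. Compound 3 is estimated at 7 mL.min-1.g-1, with an expected range of 3.5 mL.min-1.g-1 to 14 mL.min-1.g-1.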

Compound 3, intrinsic clearance in microsomes: 3.9 mL.min-1.g-1
Beside the measured number, compound 3's estimate is 1.8-fold (0.25 log units) above it; measured number inside the range.
By their numbers in this assay, from the lowest: compounds 3, 1 and 2 (each within the scatter of the next, the first and the last beyond it).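

In this assay, for the compounds shown here, the step of a 2.5-fold lower number from compound 2 to compound 3 (0.39 log units; beyond the scatter) is the first at this amide-type nitrogen to go beyond the scatter, with oxolan-3-yl in place of 1-(methoxymethyl)propyl. The step of a 1.5-fold lower number from compound 1 to compound 3 (0.17 log units; within the scatter) stays within the scatter, so the ring is separated only from the longer open chain, not from 1-(methoxymethyl)ethyl. No evidence at hand bears on this result.

Still open, on these data alone, is whether the ring oxygen matters, which cyclopentyl on this nitrogen would test. Oxan-4-yl would show whether a six-membered ring gives a similar number.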